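The source may hold more compounds than are shown below. What is called first, only, known or untested is meant among the compounds shown, and "the series" means these compounds.

Measured compounds:
Compound 1 `CC(C(=O)NCc1ccc(C(F)(F)F)nc1SCCOc1ccccc1)c1ccc(NS(C)(=O)=O)c(F)c1`: in an assay on CHO-K1 cells for antagonist activity at transient receptor potential cation channel subfamily V member 1 (Homo sapiens), read by FLIPR (on this read-out higher numbers stand for weaker inhibition and lower numbers for stronger inhibition), compound 1 gives 2.3 nM.
Compound 2 `CC1CCN(CCCSc2nc(C(F)(F)F)ccc2CNC(=O)C(C)c2ccc(NS(C)(=O)=O)c(F)c2)CC1`: in this assay compound 2 gives 2.9 nM.
Compound 3 `COC(=O)CCSc1nc(C(F)(F)F)ccc1CNC(=O)C(C)c1ccc(NS(C)(=O)=O)c(F)c1`: in this assay compound 3 gives 48.2 nM.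

Compound 2 holds the second highest of the three numbers in this assay, with compound 1 as its nearest neighbour and compound 3 as its furthest. The next compound, compound 4 `CC(C(=O)NCc1ccc(C(F)(F)F)nc1SCc1ccc(Cl)cc1)c1ccc(NS(C)(=O)=O)c(F)c1`, differs from compound 2 by 4-chlorophenyl in place of 2-(4-methylpiperidin-1-yl)ethyl on a saturated chain carbon bound to a sulfur. Two kinds of step at this position have been measured. Exchanging phenoxy for (4-methylpiperidin-1-yl)methyl left the number essentially where it was, a 1.3-fold higher number from compound 1 to compound 2 (0.10 log units; within the scatter). Exchanging either of these for methoxycarbonyl cost a great deal, a 21-fold higher number from compound 1 to compound 3 (1.32 log units; beyond the scatter) and a 17-fold higher number from compound 2 to compound 3 (1.22 log units; beyond the scatter). The entering 4-chlorophenyl, a six-membered aromatic ring of carbon only, stands closer in kind to the phenoxy of compound 1 than to the methoxycarbonyl of compound 3, so in this assay no step beyond the scatter is expected from compound 2 to compound 4, a 1.4-fold higher number from compound 2 to compound 4 (0.14 log units; within the scatter). Compound 4 is therefore estimated at 4 nM, in the range 1.5 nM to 15 nM.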

Compound 4, inhibition constant: 8.7 nM
For compound 4 the middle estimate is 2.2-fold (0.34 log units) below the measured one; low and high end bracket the measured number.
By their numbers in this assay, from the lowest: compounds 1 and 2 (each within the scatter of the next); then compound 4; then compound 3.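

In this assay, among the compounds shown here, the 4-chlorophenyl change is the first at this position, on a saturated chain carbon bound to a sulfur, that separates from both compound 1 and compound 2 by a modest step beyond the scatter (a 3.8-fold higher number from compound 1 to compound 4 (0.58 log units; beyond the scatter)) and (a 3.0-fold higher number from compound 2 to compound 4 (0.48 log units; beyond the scatter)). It still retains much of what methoxycarbonyl loses (a 5.5-fold lower number from compound 3 to compound 4 (0.74 log units; beyond the scatter)), so the position now shows an intermediate level rather than only two levels. No measurement shown here explains this ordering.

The compounds shown do not separate the effect of the chlorine from that of the shorter link, since 4-chlorobenzyl differs from phenoxymethyl-bearing and piperidine-bearing chains in both. Plain benzyl, 2-(4-chlorophenyl)ethyl and a carboxylic acid in place of methoxycarbonyl remain open at this position.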